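The source may report more compounds than this note shows. Statements on the series, on what has been measured and on what is new or still open speak of the compounds shown alone.

Notes on the series in a functional assay, with a stated time of 150 min, tested at 5 ug/mL; on this read-out higher numbers stand for a stronger effect at the one concentration tested and lower numbers for a weaker effect. Compound 1 `COC(=O)c1c(Nc2ccccc2)sc(C(=O)c2ccc(OC)cc2)c1C` gives 13.3% in this assay. Compound 2 `COC(=O)c1c(Nc2ccccc2)sc(C(=O)c2ccc(C)cc2)c1C` gives 2.08%. Compound 3 `COC(=O)c1c(Nc2ccc(Cl)cc2)sc(C(=O)c2ccc(C)cc2)c1C` is reported as "not active" (no number reported), without a number. Among the two compounds with a number, compound 2 stands lowest; its nearest neighbour is compound 1, and the single measured step, a number 11.2 percentage points lower from compound 1 to compound 2 (beyond the scatter), is the methyl in place of methoxy on an aromatic carbon, a modest drop beyond the scatter.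

Compound 4 `Cc1ccc(C(=O)c2sc(Nc3ccccc3)c(C(=O)O)c2C)cc1` awaits measurement. It differs from compound 2 in one place: hydrogen in place of methyl on an oxygen next to a carbonyl group. Within the data shown here, no measured step touches the methoxycarbonyl group; the only step available, a number 11.2 percentage points lower from compound 1 to compound 2 (beyond the scatter), concerns the aromatic carbon and gives no direct guide to a change at the carboxy position. With compound 2 already low in this assay and nothing to suggest a rise, the expected step is small and within the scatter. The estimate for compound 4 in this assay is therefore 3%, with a range from 0% to 15%, which corresponds to an expected step of a number 0.9 percentage points higher from compound 2 to compound 4 (within the scatter). Compound 3 was reported as "not active" (no number reported) with no number, and a report of that kind remains possible for compound 4.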

Compound 4, a percentage reported as activity, at one concentration (the size of the read-out at that concentration, not a potency): 0.26%
The estimate for compound 4 lay 2.7 percentage points above the measured number; the range from low to high includes it.
By their numbers in this assay, from the lowest: compounds 4 and 2 (each within the scatter of the next); then compound 1.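

In this assay, among these compounds, the replacement of methoxycarbonyl by carboxy gives a number 1.8 percentage points lower from compound 2 to compound 4 (within the scatter), the first reading of any change at this position. Hydrogen in place of methyl on an oxygen next to a carbonyl group therefore leaves compound 2 and compound 4 indistinguishable on this read-out, so this single pair shows no gain from the carboxy group and no measurable loss from removing the methyl. No measurement accompanies this result that could account for it.

From the compounds shown here alone, this pair is read only with the methyl on the aromatic carbon of compound 2 and a low starting value, so a further fall would be hard to see, and it remains open whether the same replacement would act differently with the methoxy of compound 1, where the starting number is higher. Also open is how a primary amide, an ethyl ester or a longer alkyl ester in place of the methoxycarbonyl would read at the one concentration tested, since the compounds shown cover only the methyl ester and the carboxylic acid.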